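Cytotoxicity on Vero cells across a shared aryl ketone series

A few compounds are considered here, and "the series" means these few. Any claim that something is new, unique, unknown or untested is made for them only; others in the source may bear on it.

Three compounds share one core and differ only in the aromatic ring attached to a carbonyl carbon. Compound 1 `COC(=O)c1cc(-c2cccc(NC(=O)c3ccc(/C=C/C(=O)c4cccc(Br)c4)cc3)c2)on1` carries a bromophenyl ring there; compound 2 `COC(=O)c1cc(-c2cccc(NC(=O)c3ccc(/C=C/C(=O)c4cccnc4)cc3)c2)on1` carries a pyridin-3-yl ring; compound 3 `COC(=O)c1cc(-c2cccc(NC(=O)c3ccc(/C=C/C(=O)c4ccc(OC)cc4OC)cc3)c2)on1` carries a 2,4-dimethoxyphenyl ring. The measure is an ADME assay on Vero cells (Chlorocebus sabaeus) for cytotoxicity, read by MTT assay, with a stated time of 72 h; on this read-out higher numbers stand for lower toxicity in this test and lower numbers for higher toxicity in this test. In this assay compound 1 gives > 100 ug/mL, which is a limit of the assay rather than a number. For compound 2 the result in this assay is "not determined" (no result reported), so its standing on the numbers shown cannot be placed. The change from compound 2 to compound 3 is 2,4-dimethoxyphenyl in place of pyridin-3-yl on a carbonyl carbon. Within the data shown here, with no measured step between two compounds, the only guidance is that the one recorded value, that of compound 1, sits at the limit of > 100 ug/mL in this assay, at which 1 of the 2 values shown sits. The expectation for this assay is therefore no step beyond the usual scatter, with compound 3 also likely to show little toxicity. Compound 3 is estimated at 100 ug/mL, within a range of 30 ug/mL to 300 ug/mL.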

Compound 3, half-maximal cytotoxic concentration: > 50 ug/mL
Compound 3 gave a limit, no number (the forecaster's own chance of this, stated with the estimate: 60%); the middle value lies beyond the limit too.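

Compound 1 gives > 100 ug/mL, which is a limit and not a number. Among these compounds, compound 3 gives > 50 ug/mL, also a limit, so no step from compound 1 to compound 3 can be read. The compounds shown leave open whether 3-bromophenyl and 2,4-dimethoxyphenyl differ at all in toxicity, and where compound 2 stands.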